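The compounds below may be only part of what the source reports. "The series", "measured", "known", "first", "only" and "open" are said of these compounds alone.

- Compound 1 `CNC(=O)c1ccccc1Oc1nc(Nc2ccc(C(F)(F)F)cc2)ncc1Br`: > 50000 nM
- Compound 2 `COc1cc(Nc2nccc(NCCCN)n2)cc(OC)c1OC`: 45800 nM

In a functional assay on MDA-MB-468 cells (Homo sapiens) for antiproliferative activity, read by MTT assay, with a stated time of 24 h (on this read-out lower numbers stand for stronger inhibition and higher numbers for weaker inhibition), compound 1 gives > 50000 nM, which is a limit and not a number. Within the data shown here, compound 2, at 45800 nM, holds the only actual number so far. Compound 3 `COc1cc(Nc2ncc(I)c(NCCCN)n2)cc(OC)c1OC` differs from compound 2 in one place: iodo in place of hydrogen on an aromatic carbon. Among the measured compounds shown here, no measured pair shows what this swap does, so only a modest shift towards stronger inhibition is expected, and with low confidence. The expected change is a 2.3-fold lower number from compound 2 to compound 3 (0.36 log units; beyond the scatter). The estimate for compound 3 is 20000 nM, expected to fall within 6000 nM to 50000 nM.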

Compound 3, half-maximal inhibitory concentration: > 50000 nM
Compound 3 was reported as a limit; the forecaster's own chance of this, stated with the estimate: 20%; at least 2.5-fold (0.39 log units) between middle value and limit.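

In this assay compound 3, which carries iodo on the aromatic carbon ortho to the (3-aminopropyl)amino group, is reported only as a limit, > 50000 nM. The step is an at least 1.0-fold higher number from compound 2 to compound 3 (0.03 log units; that floor lies within the scatter), so the swap gives no sign of stronger inhibition. How much weaker compound 3 might be stays hidden because the read-out stops at a ceiling: the limit of > 50000 nM in this assay, at which 2 of the 3 values shown sit.

Going by these compounds, whether chloro, a methyl group or an amine at this position would give a real number in this assay remains open.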